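The compounds below may be only part of what the source reports. "The series", "measured", "known", "first", "only" and "open" are said of these compounds alone.

In a functional assay on HL-60 cells (Homo sapiens) for inhibition, read by MTT assay, with a stated time of 72 h (on this read-out lower numbers stand for stronger inhibition and higher numbers for weaker inhibition), three compounds sharing one core have been measured, and they differ only in the aromatic group on the core. Compound 2 `Cc1ccc(C)c(N2CCN(C(=O)c3oc(C)nc3-c3ccccc3)CC2)c1`, which has no fluoro on that group, gives 31.3 nM. Compound 1 `Cc1ccc(C)c(N2CCN(C(=O)c3oc(C)nc3-c3ccc(F)cc3)CC2)c1`, with 4-fluorophenyl, gives 358 nM, and compound 3 `Cc1ccc(C)c(N2CCN(C(=O)c3oc(C)nc3-c3ccccc3F)CC2)c1`, with 2-fluorophenyl, gives 319 nM. Compound 3 therefore stands level with compound 1, as a 1.1-fold lower number from compound 1 to compound 3 (0.05 log units; within the scatter) shows, and well apart from compound 2, with a 10-fold higher number from compound 2 to compound 3 (1.01 log units; beyond the scatter).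

Compound 4 `Cc1ccc(C)c(N2CCN(C(=O)c3oc(C)nc3-c3ccc(Cl)cc3)CC2)c1` has not yet been measured. The change leading to it is 4-chlorophenyl in place of 2-fluorophenyl on an aromatic carbon, which places 4-chlorophenyl in place of 2-fluorophenyl on an aromatic carbon.

Going by the values given here, three measured steps bear on this. Among the compounds with values here, removing the fluoro gave large steps, an 11-fold lower number from compound 1 to compound 2 (1.06 log units; beyond the scatter) and the one already cited for compound 3, so both fluoro compounds sit far from compound 2. Moving the fluoro between the two places changed nothing beyond the scatter. Within the data shown here, no chloro compound has been measured, so the swap of halogen itself remains untested, and compound 1 is the nearest guide. In this assay, the expected outcome is therefore no step beyond the scatter, estimated as a 1.1-fold lower number from compound 3 to compound 4 (0.03 log units; within the scatter). Compound 4 is expected to give about 300 nM, with an estimated range of 90 nM to 1000 nM.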

Compound 4, half-maximal inhibitory concentration: "not active" (no number reported)
The entry for compound 4 holds no number, and the estimate cannot be compared.
By their numbers in this assay, from the lowest: compound 2; then compounds 3 and 1 (each within the scatter of the next).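

In this assay, going by these compounds alone, compound 4 is reported as "not active" without a number, so no step linking it to compound 1, compound 2 or compound 3 can be read. The compounds shown leave open how far 4-chlorophenyl on the shared core lies from 4-fluorophenyl or from the unsubstituted phenyl. Nothing measured here accounts for this entry.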